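The source may report more compounds than this note shows. Statements on the series, on what has been measured and on what is new or still open speak of the compounds shown alone.

Working notes on the series. The shared core carries a hydroxyformamide or hydroxybenzamide on a chain carbon next to an aromatic ring that bears a benzyloxy-type substituent. Compound 1 `CC(c1ccc(OCc2ccccc2)cc1)N(O)C=O` gives 940 nM in an assay on RBL-1 cells for inhibition of Polyunsaturated fatty acid 5-lipoxygenase (Rattus norvegicus); a higher number here means a weaker inhibitor, a lower number a stronger inhibitor. Compound 2 `CC(c1ccc(OCc2ccccc2)cc1)N(O)C(=O)c1ccccc1` gives 690 nM in this assay. Among the measured compounds shown here, the only step measured so far is a 1.4-fold lower number from compound 1 to compound 2 (0.13 log units; within the scatter), a change on the carbonyl carbon. On the numbers to hand compound 2 has the lowest value of the two, but its distance from compound 1 lies within the scatter, so no order between them can be claimed.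

Compound 3 `CC(c1ccc(OCc2ccc3ccccc3n2)cc1)N(O)C(=O)c1ccccc1` differs from compound 2 by quinolin-2-yl in place of phenyl on a saturated chain carbon bound to an oxygen on an aromatic ring. For the measured compounds named here, no measured step touches this place; the step from compound 1 to compound 2 concerns the carbonyl carbon and gives no guidance on the benzylic group. Going by the values given here, with no step to lean on, no shift beyond the scatter is expected, and compound 3 is estimated at 500 nM in this assay, range 120 nM to 2000 nM, which corresponds to an expected step of a 1.4-fold lower number from compound 2 to compound 3 (0.14 log units; within the scatter).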

Compound 3, half-maximal inhibitory concentration: 400 nM
Estimate against measurement, compound 3: 1.3-fold (0.10 log units) above; low and high end bracket the measured number.
By their numbers in this assay, from the lowest: compounds 3, 2 and 1 (each within the scatter of the next, the first and the last beyond it).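

Quinolin-2-yl in place of phenyl on a saturated chain carbon bound to an oxygen on an aromatic ring gives a 1.7-fold lower number from compound 2 to compound 3 (0.24 log units; within the scatter) in this assay. Among the compounds shown here, this is the first reading at this place, and it shows that the larger bicyclic group, which brings a ring nitrogen and a hydrogen-bond acceptor, is tolerated here with no shift beyond the scatter, so phenyl is not required at this place on the hydroxybenzamide background. Nothing at hand bears on the reason for this result.

From the compounds shown here alone, the change has been read on the hydroxybenzamide only, so its outcome on the hydroxyformamide of compound 1 remains open. Also open, going by these compounds, is what an amine or a carboxylic acid at this same place, or a longer chain on the carbonyl carbon, would give.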